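Trimming the amide tail: plain piperidine in compound 4

The source may report more compounds than this note shows. Statements on the series, on what has been measured and on what is new or still open speak of the compounds shown alone.

Compound 1 `CC(C)(C)OC(=O)NCC1CCCN(C(=O)CN2CN(c3ccccc3)C3(CCN(C(=O)c4ccc(C5CCCCC5)cc4)CC3)C2=O)C1` gives 3800 nM in an assay on HEK293 cells for displacement of a labelled ligand from NPC1-like intracellular cholesterol transporter 1 (Homo sapiens); on this read-out lower numbers stand for stronger inhibition and higher numbers for weaker inhibition.
Compound 2 `CCC1CCCN(C(=O)CN2CN(c3ccccc3)C3(CCN(C(=O)c4ccc(C5CCCCC5)cc4)CC3)C2=O)C1` gives 2600 nM in this assay.
Compound 3 `COC(=O)CCCNC(=O)CN1CN(c2ccccc2)C2(CCN(C(=O)c3ccc(C4CCCCC4)cc3)CC2)C1=O` gives 2500 nM in this assay.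

Compound 3 carries the lowest of the three numbers, yet its gaps to compound 2 and to compound 1 both sit within the scatter, so no ordering can be read from them. Compound 4 `O=C(CN1CN(c2ccccc2)C2(CCN(C(=O)c3ccc(C4CCCCC4)cc3)CC2)C1=O)N1CCCCC1` differs from compound 3 by piperidin-1-yl in place of (3-(methoxycarbonyl)propyl)amino on a carbonyl carbon. Two earlier steps touch the same amide end of the shared core: a 1.5-fold lower number from compound 1 to compound 2 (0.16 log units; within the scatter) and a 1.0-fold lower number from compound 2 to compound 3 (0.02 log units; within the scatter). Both stayed within the scatter, so this region has so far absorbed changes without moving the read-out. Compound 4 is therefore expected to stay near compound 3, with a 1.1-fold higher number from compound 3 to compound 4 (0.05 log units; within the scatter) of no real size. The estimate for compound 4 is 2800 nM, ranging from 1200 nM to 6500 nM.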

Compound 4, half-maximal inhibitory concentration: 1100 nM
For compound 4 the middle estimate is 2.5-fold (0.41 log units) above the measured one; the whole stated range lies above it.
By their numbers in this assay, from the lowest: compound 4; then compounds 3, 2 and 1 (each within the scatter of the next).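

In this assay, within the data shown here, piperidin-1-yl on the carbonyl carbon gives a 2.3-fold lower number from compound 3 to compound 4 (0.36 log units; beyond the scatter) and so moves the number beyond the scatter, which no step among compounds 1, 2 and 3 did. The bare ring also differs from its substituted forms: hydrogen in place of ethyl gives a 2.4-fold lower number from compound 2 to compound 4 (0.37 log units; beyond the scatter) and hydrogen in place of ((tert-butoxycarbonyl)amino)methyl gives a 3.5-fold lower number from compound 1 to compound 4 (0.54 log units; beyond the scatter) so both of these ring substituents go with modestly higher numbers.

As far as these compounds go, whether a pyrrolidine or a morpholine on this carbonyl carbon would give a lower number still stays open. Nothing available explains this drop.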